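The compounds below may be only part of what the source reports. "The series", "measured", "known", "first", "only" and "open" are said of these compounds alone.

Of the compounds shown here, three have been tested in a functional assay on the whole organism (strain Sprague-Dawley) for inhibition, with Rattus norvegicus as the target (a higher number here means that more compound is needed for the effect, a lower number that less compound is needed), and a fourth awaits its number. Compound 3 `O=c1c(-c2nn[nH]n2)c[nH]c2ccccc12` gives 1.25 mg/kg in this assay. Compound 1 `COc1ccc2c(=O)c(-c3nn[nH]n3)c[nH]c2c1` differs from it by one change, (methoxy in place of hydrogen on an aromatic carbon), and gives 10 mg/kg; the step of an 8.0-fold higher number from compound 3 to compound 1 (0.90 log units; beyond the scatter). Compound 2 `COc1cccc2cc(-c3nn[nH]n3)cnc12` rests on a different core, and the difference between the two cores is not broken down here; in this assay compound 2 gives 2.5 mg/kg, which sits within the scatter of compound 3 and is a lower number than compound 1.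

Compound 4 `COc1ccc(OC)c2ncc(-c3nn[nH]n3)cc12` is not yet measured. It arises from compound 2 by methoxy in place of hydrogen on an aromatic carbon. For the measured compounds named here, this is the same kind of change as the one from compound 3 to compound 1, though the surroundings differ: in compound 4 the entering group is ortho to a fused ring, meta to a fused ring and para to a methoxy group, whereas in compound 1 it is meta to a fused ring and para to a fused ring. Resting on the step from compound 3 to compound 1, the step from compound 2 to compound 4 is expected to be a 4.0-fold higher number from compound 2 to compound 4 (0.60 log units; beyond the scatter), somewhat smaller given the changed surroundings. For compound 4 the expected value is therefore 10 mg/kg, between 2.5 mg/kg and 40 mg/kg.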

Compound 4, minimum effective dose: 5 mg/kg
Compound 4: the middle estimate sits 2.0-fold (0.30 log units) above what was measured; the measured number falls inside the stated range.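

In this assay, for the compounds shown here, methoxy in place of hydrogen on an aromatic carbon gives a 2.0-fold higher number from compound 2 to compound 4 (0.30 log units; within the scatter), so on the core of compound 2 this change produces no step that can be told apart from repeat measurement. Set beside the earlier step, the same change does not carry over at the same size from one core to the other: the same change on two cores in this assay, an 8.0-fold higher number (0.90 log units; beyond the scatter) from compound 3 to compound 1 and a 2.0-fold higher number (0.30 log units; within the scatter) from compound 2 to compound 4, 4.0-fold (0.60 log units) apart, beyond the scatter of two such steps. This rests on a single pair per core, and the entering group stands in different surroundings in the two pairs, including para to a methoxy group in compound 4, so the data cannot separate the effect of the core from that of the surroundings and give no reason for the gap.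

The compounds shown leave open whether a group other than methoxy, such as chlorine, a hydroxyl or an amine, would also differ between the two cores. They also leave open whether methoxy at another carbon of either core would give a step of similar size.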